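The source may hold more compounds than are shown below. What is called first, only, known or untested is meant among the compounds shown, and "the series" means these compounds.

The three measured compounds are compound 1 `CCCSc1nc(N/N=C/c2cccs2)c2nnn(Cc3ccccc3)c2n1`, compound 2 `CCCSc1nc(N/N=C(\C)c2ccc(O)cc2)c2nnn(Cc3ccccc3)c2n1` and compound 3 `CCCSc1nc(N/N=C(\C)c2ccc(Br)cc2)c2nnn(Cc3ccccc3)c2n1`. In a functional assay on ECa-109 cells (Homo sapiens) for antiproliferative activity, read by MTT assay, with a stated time of 72 h (a higher number here means a weaker inhibitor, a lower number a stronger inhibitor), compound 1 gives only a limit of the assay, > 64000 nM. In this assay compound 2 gives 32500 nM, and compound 3 gives 4670 nM. Compound 1 stands apart in that (the limit of > 64000 nM in this assay, at which 1 of the 3 values shown sits).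

The unmeasured compound 4 `CCCSc1nc(N/N=C/c2c(O)ccc3ccccc23)c2nnn(Cc3ccccc3)c2n1` differs from compound 1 in one place: 2-hydroxynaphthalen-1-yl in place of thiophen-2-yl on a carbon with a double bond to nitrogen. Within the data shown here, two measured steps bear on this exchange of a five-membered sulfur-containing ring for a six-membered carbon ring on the carbon with a double bond to nitrogen: an at least 1.9-fold lower number from compound 1 to compound 2 (0.29 log units; that floor lies within the scatter) and an at least 13-fold lower number from compound 1 to compound 3 (1.13 log units; beyond the scatter). Both run toward a lower number, though the floor of the first lies within the scatter. Between the two, a 7.0-fold lower number from compound 2 to compound 3 (0.84 log units; beyond the scatter) shows that the hydroxy-bearing ring gave the smaller change. Since compound 4 also carries a hydroxy group on its entering ring, the step from compound 1 to compound 2 seems the closer guide, and the expectation rests on it. For compound 4 the expected step is an at least 2.9-fold lower number from compound 1 to compound 4 (0.46 log units; beyond the scatter), a lowering that may not clearly exceed the scatter. Compound 4 is estimated at 22000 nM, within a range from 5000 nM to 64000 nM.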

Compound 4, half-maximal inhibitory concentration: 9290 nM
Estimate against measurement, compound 4: 2.4-fold (0.37 log units) above, within the range that was stated.
By their numbers in this assay, from the lowest: compounds 3 and 4 (each within the scatter of the next); then compound 2. At a limit, above all of these: compound 1.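

In this assay, 2-hydroxynaphthalen-1-yl in place of thiophen-2-yl on the carbon with a double bond to nitrogen gives an at least 6.8-fold lower number from compound 1 to compound 4 (0.83 log units; beyond the scatter). The earlier hydroxy-bearing exchange, an at least 1.9-fold lower number from compound 1 to compound 2 (0.29 log units; that floor lies within the scatter), could not settle whether a group carrying a hydroxy can clearly lower the number here, whereas this new step shows that one can. Compound 1 stands at a limit of the assay and not at a number, so the new step gives only a floor, and its true size could be larger: the limit of > 64000 nM in this assay, at which 1 of the 4 values shown sits.

The compounds shown leave open how much of this step belongs to the hydroxy group and how much to the second aromatic ring, a question that a plain naphthalen-1-yl group at the same place would help to separate. Going by these compounds, it also remains open whether an amine or a carboxylic acid in place of that hydroxy group would keep, lower or raise the number in this assay.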